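The source may hold more compounds than are shown below. What is called first, only, known or untested is meant among the compounds shown, and "the series" means these compounds.

Working notes on the series. Compound 1 `CCCCCCCCCCCCNC(=O)[C@@H](NC(=O)c1ccccc1)[C@@H](C)O` carries a phenyl group on the carbonyl carbon attached to the amide-type nitrogen; in a functional assay on A-431 cells (Homo sapiens) for cytotoxicity, read by MTT assay, with a stated time of 48 h (a lower number here means a stronger inhibitor, a higher number a weaker inhibitor), compound 1 gives 41200 nM. Compound 2 `CCCCCCCCCCCCNC(=O)[C@@H](NC(=O)c1nccc2ccccc12)[C@@H](C)O` has isoquinolin-1-yl in that place, and in this assay compound 2 gives 62800 nM. Going by the values given here, the only measured step, a 1.5-fold higher number from compound 1 to compound 2 (0.18 log units; within the scatter), leaves the two compounds within the scatter of each other, so compound 2 stands at the higher of the two numbers without any real separation from compound 1.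

Compound 3 `C/C=C/C=C/C(=O)N[C@H](C(=O)NCCCCCCCCCCCC)[C@@H](C)O` is the next case. Its difference from compound 2 is penta-1,3-dien-1-yl in place of isoquinolin-1-yl on a carbonyl carbon. Among the compounds with values here, no measured step covers an exchange of an aromatic group for an open chain at this position; the one step available, a 1.5-fold higher number from compound 1 to compound 2 (0.18 log units; within the scatter), only shows that swapping phenyl for isoquinolin-1-yl moved nothing beyond the scatter. On that basis no step beyond the scatter is expected for compound 3 in this assay, and the expected step is a 1.3-fold lower number from compound 2 to compound 3 (0.10 log units; within the scatter). For compound 3 the estimate in this assay is 50000 nM, with a range from 15000 nM to 150000 nM.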

Compound 3, half-maximal inhibitory concentration: 171000 nM
Estimate against measurement, compound 3: 3.4-fold (0.53 log units) below; the whole stated range lies below it.
By their numbers in this assay, from the lowest: compounds 1 and 2 (each within the scatter of the next); then compound 3.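

In this assay, going by these compounds alone, the carbonyl carbon whose other neighbour is the amide-type nitrogen proves not to be indifferent to its group: penta-1,3-dien-1-yl gives a 2.7-fold higher number from compound 2 to compound 3 (0.44 log units; beyond the scatter) and a 4.2-fold higher number from compound 1 to compound 3 (0.62 log units; beyond the scatter), both modest but the first steps to pass beyond the scatter. Among the three compounds shown, the two groups with an aromatic ring, phenyl and isoquinolin-1-yl, remain within the scatter of each other, while the open chain with two double bonds stands apart on the weaker side, and no compound here goes against that split. No supporting measurement is available to explain this separation.

The compounds shown leave open whether the step follows the loss of the aromatic ring, the open chain itself or its double bonds, since penta-1,3-dien-1-yl differs from both aromatic groups in all of these at once. A pentyl or cyclohexyl group on the same carbonyl carbon would help separate these features, and a pyridin-2-yl group would show whether a smaller aromatic ring with one nitrogen stays with compound 1 and compound 2.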